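The source may hold more compounds than are shown below. What is called first, only, known or untested is meant among the compounds shown, and "the series" means these compounds.

In a functional assay on HeLa cells (Homo sapiens) for antiproliferative activity, with a stated time of 5 days (on this read-out lower numbers stand for stronger inhibition and higher numbers for weaker inhibition), compound 1 `COc1ccc(-n2nc(-c3ccc4ccccc4c3)nc2N2C(=O)COC23C=CC(=O)C=C3)cc1` gives 200 nM and compound 2 `O=C1C=CC2(C=C1)OCC(=O)N2c1nc(-c2ccc3ccccc3c2)nn1-c1ccc2ccccc2c1` gives 210 nM. Among the measured compounds shown here, compound 2 therefore stands level with compound 1, the only other number so far, as the measured change is a 1.1-fold higher number from compound 1 to compound 2 (0.02 log units; within the scatter). Compound 3 `O=C1C=CC2(C=C1)OCC(=O)N2c1nc(-c2ccc3ccccc3c2)nn1-c1ccc(Cl)cc1` changes the same place on the shared core: 4-chlorophenyl in place of naphthalen-2-yl on an aromatic nitrogen. There, 4-chlorophenyl stands in place of naphthalen-2-yl on an aromatic nitrogen. For the measured compounds named here, the one measured step bearing on this swap is the exchange of 4-methoxyphenyl for naphthalen-2-yl, which gave a 1.1-fold higher number from compound 1 to compound 2 (0.02 log units; within the scatter). Going by the values given here, no measured compound yet carries chlorine, so this single step is thin support. On that evidence, no change beyond the scatter is expected in this assay. The expected step is a 1.1-fold lower number from compound 2 to compound 3 (0.02 log units; within the scatter). Compound 3 is estimated at 200 nM, with an expected range from 95 nM to 420 nM.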

Compound 3, half-maximal inhibitory concentration: 720 nM
The estimate for compound 3 lay 3.6-fold (0.56 log units) below the measured number, outside the stated range (above it).
By their numbers in this assay, from the lowest: compounds 1 and 2 (each within the scatter of the next); then compound 3.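

In this assay the group on this aromatic nitrogen now makes a difference: 4-methoxyphenyl and naphthalen-2-yl could not be told apart, but 4-chlorophenyl gives a 3.4-fold higher number from compound 2 to compound 3 (0.54 log units; beyond the scatter). Chloro in place of methoxy on an aromatic carbon gives a 3.6-fold higher number from compound 1 to compound 3 (0.56 log units; beyond the scatter), so the single ring of compound 3 cannot by itself account for the rise, since compound 1 also has a single ring there and stands level with the two-ring compound 2. The data shown give no cause for this rise. From the compounds shown here alone, it remains open whether the higher number follows from the chloro group itself or from the absence of methoxy. Also open, going by these compounds, is whether an amine or a carboxylic acid in that place on the phenyl ring would stand with compound 1 or with compound 3.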